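Benzyl for Benzoyl on an Oxygen

This account rests on a few compounds, and the source may have more. Where it says the series, first, only, none or still open, it means among the compounds named here.

Measured so far in a functional assay on MDA-MB-231 cells (Homo sapiens) for antiproliferative activity, read by MTT assay, with a stated time of 72 h; on this read-out lower numbers stand for stronger inhibition and higher numbers for weaker inhibition:
Compound 1 `CC1=CC[C@H]2[C@H](CC[C@]2(C)O)C(C)(C)[C@@H]1CC[C@H]1[C@]2(C)CC/C(=N/O)C(C)(C)O[C@H]2CC[C@@]1(C)O` gives 42700 nM
Compound 2 `CC1=CC[C@H]2[C@H](CC[C@]2(C)O)C(C)(C)[C@@H]1CC[C@H]1[C@]2(C)CC/C(=N/OC(=O)c3ccccc3)C(C)(C)O[C@H]2CC[C@@]1(C)O` gives 27400 nM

Compound 2 can be compared only with compound 1, and the two values lie within the scatter of each other, so neither can be ranked above the other. Compound 3 `CC1=CC[C@H]2[C@H](CC[C@]2(C)O)C(C)(C)[C@@H]1CC[C@H]1[C@]2(C)CC/C(=N/OCc3ccccc3)C(C)(C)O[C@H]2CC[C@@]1(C)O` has not yet been measured. It carries benzyl in place of benzoyl on an oxygen and keeps the shared core. For the measured compounds named here, the only measured step at that oxygen is a 1.6-fold lower number from compound 1 to compound 2 (0.19 log units; within the scatter) and it put benzoyl in place of hydrogen. Going by the values given here, no measurement yet shows benzyl there. That single small step gives no ground to expect a shift beyond the scatter in this assay in either direction. The expected change is a 1.0-fold higher number from compound 2 to compound 3 (0.01 log units; within the scatter) and this estimated step stays within the scatter. The estimated value for compound 3 is 28000 nM within an expected range of 13000 nM to 55000 nM on this read-out.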

Compound 3, half-maximal inhibitory concentration: 38200 nM
For compound 3 the middle estimate is 1.4-fold (0.13 log units) below the measured one; low and high end bracket the measured number.
By their numbers in this assay, from the lowest: compounds 2, 3 and 1 (each within the scatter of the next).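

At the oxygen bound to the double-bonded nitrogen, this assay now covers a second group, and benzyl differs from benzoyl by the loss of the carbonyl and its hydrogen-bond acceptor, which gives a 1.4-fold higher number from compound 2 to compound 3 (0.14 log units; within the scatter). Measured against the free hydrogen, benzyl gives a 1.1-fold lower number from compound 1 to compound 3 (0.05 log units; within the scatter), so hydrogen, benzoyl and benzyl at this oxygen cannot be told apart on this read-out, and neither the aromatic ring nor the carbonyl separates itself from the scatter here. Nothing available explains this outcome.

As far as these compounds go, it remains open whether a basic amine, a carboxylic acid or a longer alkyl chain on this oxygen would move the number beyond the scatter. Also open, from the compounds shown here alone, is whether a substituent on the aromatic ring of the benzyl group would do so.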